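This account rests on a few compounds, and the source may have more. Where it says the series, first, only, none or still open, it means among the compounds named here.

Measured in a functional assay on NCI-H1975 cells (Homo sapiens) for cytotoxicity, read by MTT assay, with a stated time of 72 h; on this read-out lower numbers stand for stronger inhibition and higher numbers for weaker inhibition:
Compound 1 `O=C(N/N=C/c1ccc(C(F)(F)F)cc1)N1CCc2ncnc(Nc3ccc(F)c(Cl)c3)c2C1`: 36800 nM
Compound 2 `O=C(N/N=C/c1ccc(F)cc1Cl)N1CCc2ncnc(Nc3cccc(Br)c3)c2C1`: 15700 nM

Compound 2, at 15700 nM, holds the lower of the two numbers in this assay. Its gap to compound 1, at 36800 nM, lies beyond the usual scatter. Both numbers are high for this read-out, so neither compound shows strong inhibition of these cells.

The next compound to be tested is compound 3 `O=C(N/N=C/c1ccc(Br)cc1)N1CCc2ncnc(Nc3cccc(Br)c3)c2C1`. It keeps the rest of compound 2 and carries 4-bromophenyl in place of 2-chloro-4-fluorophenyl on a carbon with a double bond to nitrogen.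

For the measured compounds named here, no measured pair differs in one place only, so the data give no direct guide to the size of this step. Compound 1 and compound 2 differ in more than one place, and even their gap is modest. A step beyond the scatter in this assay is therefore not expected, in either direction. The expected change is a 1.0-fold higher number from compound 2 to compound 3 (0.01 log units; within the scatter). For compound 3 the estimated value is 16000 nM, with an expected range of 7000 nM to 38000 nM.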

Compound 3, half-maximal inhibitory concentration: 51000 nM
The estimate for compound 3 lay 3.2-fold (0.50 log units) below the measured number; the measured number lies above the stated range.
By their numbers in this assay, from the lowest: compound 2; then compounds 1 and 3 (each within the scatter of the next).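

In this assay, for the compounds shown here, putting 4-bromophenyl in place of 2-chloro-4-fluorophenyl on a carbon with a double bond to nitrogen gives a 3.2-fold higher number from compound 2 to compound 3 (0.51 log units; beyond the scatter) and provides the first comparison that differs in one place only. It shows that this position is not indifferent to the aromatic group it carries, although the step is modest and both groups are a six-membered aromatic ring of carbon only, with no hydrogen-bond donors or acceptors and no net charge. Nothing available here bears on why the number rises with this change.

This single change removes chlorine and fluorine and brings in bromine together, so the compounds shown leave open whether any one of these halogens accounts for the step, or whether it depends on all of them at once. They also leave open how this position would respond to a phenyl ring carrying an amine or a carboxylic acid, or to a pyridine ring in place of the phenyl ring, and whether the same step would appear with another group on the rest of the molecule.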